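Swapping the Furan Arm for Imidazole in Acylguanidines

The source may report more compounds than this note shows. Statements on the series, on what has been measured and on what is new or still open speak of the compounds shown alone.

Compound 1 `CC(CC(=O)/N=C(\N)NCCCc1ccccc1)c1ccccc1`: 5.89
Compound 2 `CC(CC(=O)/N=C(\N)NCCCc1ccc(CN(C)C)o1)c1ccccc1`: 6.52

In a functional assay on Sf9 cells for antagonist activity at histamine H2 receptor (Homo sapiens), with stated times of 2 min and 20 min (on this read-out higher numbers stand for higher potency (the scale is a negative logarithm) and lower numbers for lower potency), compound 2 stands highest of the two measured compounds; compound 1 sits a number 0.63 log units higher from compound 1 to compound 2 (beyond the scatter) below it. Compound 3 `CC(CC(=O)/N=C(\N)NCCCn1ccnc1)c1ccccc1` differs from compound 2 by 1H-imidazol-1-yl in place of 5-((dimethylamino)methyl)furan-2-yl on a saturated chain carbon, three bonds along the chain from an amine nitrogen. Within the data shown here, no measured step covers this exchange; the single known step, a number 0.63 log units higher from compound 1 to compound 2 (beyond the scatter), shows only that adding the furan arm raised the number beyond the scatter. Removing it and putting imidazol-1-yl in its place is therefore expected to give a moderate drop, a number 0.52 log units lower from compound 2 to compound 3 (beyond the scatter), for compound 3. Compound 3 is estimated at 6, within 5.3 to 6.7.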

Compound 3, negative logarithm of the antagonist equilibrium constant: < 5
Compound 3 gave a limit, no number (the forecaster's own chance of this, stated with the estimate: 5%); middle value at least 1.00 log units away from the limit.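

The value for compound 3 in this assay is a limit of the assay and not a number: the limit of < 5 in this assay, at which 1 of the 3 values shown sits. Even so, putting 1H-imidazol-1-yl in place of the furan arm gives a number at least 1.52 log units lower from compound 2 to compound 3 (beyond the scatter). The same group also falls short of plain phenyl at this position, with a number at least 0.89 log units lower from compound 1 to compound 3 (beyond the scatter), so here the imidazole ring matches neither earlier group.

Going by these compounds, how far compound 3 lies beyond its limit stays unknown. Also open, on these data alone, is whether a 1H-imidazol-4-yl group, or a longer chain carrying the imidazole ring, would bring the number back.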